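Benzyl for methyl on the core: outlook for compound 4

The compounds below may be only part of what the source reports. "The series", "measured", "known", "first", "only" and "open" are said of these compounds alone.

In an assay on isolated protein for inhibition of Rho-associated protein kinase 1 (Homo sapiens), tested at 30 uM (a higher number here means more inhibition at the concentration tested (going by the name of the read-out), a lower number less inhibition), compound 1 `Cn1cnc2c(Sc3ccccc3)ncnc21` gives 6%, compound 2 `Cn1cnc2c(Sc3ccc(F)cc3)ncnc21` gives 6% and compound 3 `CSc1ccc(-c2nc3c(Sc4ccc(F)cc4)ncnc3n2C)cc1` gives 0%. Compound 2 stands level with compound 1 at the digits shown, the two together the highest of the three numbers, and compound 3 is the furthest from it; every gap among the three lies within the scatter. The step of no change at the digits printed from compound 1 to compound 2 (within the scatter) brought no change, and the step of a number 6 percentage points lower from compound 2 to compound 3 (within the scatter) also stayed within the scatter.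

Compound 4 `Fc1ccc(Sc2ncnc3c2ncn3Cc2ccccc2)cc1` is not yet measured in this assay. Against compound 2 the change is phenyl in place of hydrogen on a saturated chain carbon bound to an aromatic nitrogen. Going by the values given here, neither measured step touches this place: both alter an aromatic carbon, not the saturated chain carbon bound to an aromatic nitrogen, so no measured step bears directly on the change. What the series shows is that two additions of groups elsewhere, fluoro and 4-(methylsulfanyl)phenyl, left the read-out within the scatter, and all three numbers sit low. The expectation is therefore no movement beyond the scatter, and the expected step of no change at the digits printed from compound 2 to compound 4 (within the scatter) is small. Compound 4 is estimated at 6%, with a range from -4% to 20%.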

Compound 4, a percentage reported as inhibition, at one concentration (the size of the read-out at that concentration, not a potency): 5%
For compound 4 the middle estimate is 1 percentage points above the measured one; the measured number falls inside the stated range.
By their numbers in this assay, from the lowest: compounds 3, 4, 1 and 2 (each within the scatter of the next).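

In this assay, methyl to benzyl at the saturated chain carbon bound to an aromatic nitrogen gives a number 1 percentage points lower from compound 2 to compound 4 (within the scatter), so this position now has a measured step of its own. The steps among compound 1, compound 2 and compound 3 altered only aromatic carbons, whereas this one shows that adding a phenyl at the new place also leaves the read-out within the scatter, with a low number like the others. No measurement here offers an explanation for this result.

Still open, from the compounds shown here alone, is whether any group at this place can lift the read-out beyond the scatter, for instance a longer chain such as phenethyl, or a benzyl carrying an amine or a carboxylic acid on its ring. Also open, going by these compounds, is whether benzyl on the core combined with the 4-(methylsulfanyl)phenyl of compound 3 would stay as flat, and with every number this low at a single concentration, none of the four compounds yet offers a potency to compare.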